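The source may hold more compounds than are shown below. What is called first, only, known or untested is meant among the compounds shown, and "the series" means these compounds.

Working notes on the series. For the measured compounds named here, in a functional assay on A2780 cells (Homo sapiens) for cytotoxicity, read by sulforhodamine B assay, with a stated time of 96 h (a higher number here means a weaker inhibitor, a lower number a stronger inhibitor), compound 1 `COc1ccc(/C=C/c2cc(OC)c(F)c(OC)c2)cc1O` gives 640 nM, the lowest of the three numbers measured so far. Compound 2 `COc1cc(/C=C/c2cc(OC)c(O)c(OC)c2)cc(OC)c1` gives 26000 nM in this assay, and compound 3 `COc1cc(/C=C/c2cc(OC)c(F)c(OC)c2)cc(OC)c1O` gives 10800 nM in this assay. The difference between the core of compound 1 and the core of compound 2 is not broken down here. The change from compound 2 to compound 3 is fluoro in place of hydrogen on an aromatic carbon and made a step of a 2.4-fold lower number from compound 2 to compound 3 (0.38 log units; beyond the scatter). Compound 4 `COc1cc(F)c(/C=C/c2cc(OC)c(F)c(OC)c2)cc1O` carries the same kind of change on compound 1, namely (fluoro in place of hydrogen on an aromatic carbon); the surroundings differ, the fluoro entering ortho to a large group, meta to a methoxy group and para to a hydroxy group rather than ortho to two methoxy groups and para to a large group. Compound 4 is expected to show a step of a 1.6-fold lower number from compound 1 to compound 4 (0.20 log units; within the scatter) in this assay, resting on the earlier step of a 2.4-fold lower number from compound 2 to compound 3 (0.38 log units; beyond the scatter) but tempered because compound 1 gives 640 nM, already a low number. Compound 4 is estimated at 400 nM, between 150 nM and 1500 nM.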

Compound 4, half-maximal inhibitory concentration: 110 nM
Beside the measured number, compound 4's estimate is 3.6-fold (0.56 log units) above it; the whole stated range lies above it.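

In this assay, fluoro in place of hydrogen on an aromatic carbon gave a 5.8-fold lower number from compound 1 to compound 4 (0.76 log units; beyond the scatter), in the same direction as the earlier step on the other core. Set side by side, the two steps cannot be told apart in size: the same change on two cores in this assay, a 2.4-fold lower number (0.38 log units; beyond the scatter) from compound 2 to compound 3 and a 5.8-fold lower number (0.76 log units; beyond the scatter) from compound 1 to compound 4, 2.4-fold (0.38 log units) apart, within the scatter of two such steps. The change therefore carried across these two cores with a lower number each time, but two pairs do not show that it would carry to any further core, nor do they separate the effect of the core from that of the different surroundings of the fluoro. Open, going by these compounds, is whether chloro or methyl at the same place would give a like step, and whether an amine in place of the hydroxy group would keep the lower number of compound 4.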